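The compounds below may be only part of what the source reports. "The series", "measured", "known", "first", "only" and "open" are said of these compounds alone.

Series notes. Compound 1 `O=C(O)c1ccccc1-c1ccc(CCc2ncc(CC3CCCCC3)[nH]2)cc1` gives 41 nM in an in vitro functional assay on cells for agonist activity at Bombesin receptor subtype-3 (Homo sapiens), read by luminescence and calcium flux; on this read-out lower numbers stand for an effect already at smaller amounts and higher numbers for an effect only at larger amounts of compound. Compound 2 `Cc1cccc(Cc2cnc(CCc3ccc(-c4ccccc4C(=O)O)cc3)[nH]2)c1` gives 4310 nM, and compound 3 `N#Cc1ccccc1Cc1cnc(CCc2ccc(-c3ccccc3C(=O)O)cc2)[nH]1` gives 5480 nM. Compound 3 thus carries the highest of the three numbers: it sits apart from compound 1 by a 130-fold higher number from compound 1 to compound 3 (2.13 log units; beyond the scatter), while the remaining step, a 1.3-fold higher number from compound 2 to compound 3 (0.10 log units; within the scatter), lies within the scatter.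

Compound 4 `COc1ccccc1Cc1cnc(CCc2ccc(-c3ccccc3C(=O)O)cc2)[nH]1` differs from compound 3 by methoxy in place of cyano on an aromatic carbon. Among the compounds with values here, the steps that bear on this are of two kinds. The change from a saturated ring to an aromatic one on the chain carbon, a 110-fold higher number from compound 1 to compound 2 (2.02 log units; beyond the scatter) and a 130-fold higher number from compound 1 to compound 3 (2.13 log units; beyond the scatter), was large in both cases, but compound 4 keeps the aromatic ring. Within the data shown here, the only step that exchanges one substituent on that aromatic ring for another, a 1.3-fold higher number from compound 2 to compound 3 (0.10 log units; within the scatter), stayed within the scatter. On that basis a step of a 1.1-fold lower number from compound 3 to compound 4 (0.04 log units; within the scatter) is expected, with no movement beyond the scatter in either direction. Compound 4 is estimated at 5000 nM, with a range of 1500 nM to 15000 nM.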

Compound 4, half-maximal effective concentration: 1720 nM
Estimate against measurement, compound 4: 2.9-fold (0.46 log units) above; the range from low to high includes it.
By their numbers in this assay, from the lowest: compound 1; then compound 4; then compounds 2 and 3 (each within the scatter of the next).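

Substituent exchange on the aromatic ring does move the number in this assay: methoxy in place of cyano gives (a 3.2-fold lower number from compound 3 to compound 4 (0.50 log units; beyond the scatter)), the first change at this place to go beyond the scatter. 2-Methoxyphenyl also separates from 3-methylphenyl (a 2.5-fold lower number from compound 2 to compound 4 (0.40 log units; beyond the scatter)), although that step changes both the group and its place on the ring, whereas compounds 2 and 3 remain within the scatter of each other. The gain is small beside the remaining gap to the cyclohexyl compound (a 42-fold higher number from compound 1 to compound 4 (1.62 log units; beyond the scatter)), and nothing at hand explains the difference between methoxy and cyano.

Open is whether the methoxy step depends on its place on the ring, since the compounds shown offer no matched comparison of that. Also open, as far as these compounds go, is whether a hydroxy group or an amine at this place, or a cyclopentyl ring in place of the aromatic ring, would come closer to compound 1.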